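The compounds below may be only part of what the source reports. "The series", "measured", "known", "first", "only" and "open" are said of these compounds alone.

- Compound 1 `Cc1ccc(/C(=N/NC(=S)NCCCCCC(=O)NO)c2ccccc2)cc1`: 4340 nM
- Compound 2 `C/C(=N\NC(=S)NCCCCCC(=O)NO)c1ccc(Br)cc1`: 960 nM
- Compound 3 `C/C(=N\NC(=S)NCCCCCC(=O)NO)c1cccc(C)c1`: not yet measured

In a functional assay on K562 cells (Homo sapiens) for antiproliferative activity, read by MTT assay (on this read-out lower numbers stand for stronger inhibition and higher numbers for weaker inhibition), compound 2 holds the lower of the two numbers, and its gap to compound 1 lies beyond the usual scatter. Compound 3 carries 3-methylphenyl in place of 4-bromophenyl on a carbon with a double bond to nitrogen. Among the compounds with values here, no step between measured compounds differing in one place is available, so the expectation rests on compound 2 at 960 nM and on this change alone. A modest move toward weaker inhibition is expected, with an estimated 1.6-fold higher number from compound 2 to compound 3 (0.19 log units; within the scatter). For compound 3 the estimated value is 1500 nM, with an expected range from 500 nM to 4500 nM.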

Compound 3, half-maximal inhibitory concentration: 3840 nM
Compound 3: the middle estimate sits 2.6-fold (0.41 log units) below what was measured; the measured number falls inside the stated range.
By their numbers in this assay, from the lowest: compound 2; then compounds 3 and 1 (each within the scatter of the next).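

In this assay, replacing 4-bromophenyl with 3-methylphenyl on a carbon with a double bond to nitrogen gives a 4.0-fold higher number from compound 2 to compound 3 (0.60 log units; beyond the scatter). This position therefore distinguishes two groups that have the same heavy-atom count, one six-membered aromatic ring of carbon only, and no hydrogen-bond donors or acceptors. Nothing measured here explains the difference.

The step changes both the substituent and its ring position, so the contribution of each remains unresolved. From the compounds shown here alone, how a chlorophenyl or methoxyphenyl group would behave on this carbon also remains open.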